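A Methylsulfanyl Addition on a Weak Antiproliferative Amide

A few compounds are considered here, and "the series" means these few. Any claim that something is new, unique, unknown or untested is made for them only; others in the source may bear on it.

Among the measured compounds shown here, compound 2 `NC(=O)c1c(NC(=O)c2ccccc2)sc2c1CCN(C(=S)Nc1ccccc1Cl)C2` is one of two compounds so far assessed in a functional assay on HL-60 cells (Homo sapiens) for antiproliferative activity, with a stated time of 24 h; a higher number here means a weaker inhibitor, a lower number a stronger inhibitor. In this assay compound 2 gives 13800 nM, the higher of the two numbers. Compound 1 `N#Cc1ccccc1CN1CCc2c(sc(NC(=O)c3ccccc3Cl)c2C(N)=O)C1` gives 10400 nM; the two numbers sit within the scatter of each other, so neither compound can be set above the other on this evidence.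

Compound 3 `CSc1ccccc1C(=O)Nc1sc2c(c1C(N)=O)CCN(C(=S)Nc1ccccc1Cl)C2` has not yet been measured. It differs from compound 2 in one place: methylsulfanyl in place of hydrogen on an aromatic carbon. For the measured compounds named here, no measured pair in this small set shows what such a change does to the read-out, so there is no basis in the data for a step in either direction. Both available numbers lie in the same weak range, and nothing among them points to a departure from it.

The step of a 1.5-fold lower number from compound 2 to compound 3 (0.19 log units; within the scatter) is therefore expected to be small and of uncertain direction, not clearly beyond the scatter. The estimate for compound 3 in this assay is 9000 nM, expected to fall between 3000 nM and 30000 nM.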

Compound 3, half-maximal inhibitory concentration: 30500 nM
For compound 3 the middle estimate is 3.4-fold (0.53 log units) below the measured one, outside the stated range (above it).
By their numbers in this assay, from the lowest: compounds 1 and 2 (each within the scatter of the next); then compound 3.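

In this assay, among the compounds shown here, the change of benzamido to ((2-(methylsulfanyl)phenyl)carbonyl)amino gives a 2.2-fold higher number from compound 2 to compound 3 (0.34 log units; beyond the scatter), the first step in this set that can be read, and it runs towards a weaker inhibitor. It shows that this aromatic carbon, ortho to a large group, does not accept every replacement of its hydrogen without a change in the read-out, although the step is modest and compound 3, at 30500 nM, remains a weak inhibitor. No measurement shown here accounts for the direction or size of this step.

The compounds shown leave open whether the higher number is particular to methylsulfanyl or would also follow from another group on the same carbon, such as fluorine, methoxy or hydroxyl. For the compounds shown here, they also leave open whether a step of this kind would carry over to a compound with the other substituents of compound 1, whose benzoyl group already bears chlorine and whose shared core carries a different group from the one in compound 2.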